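Plasma protein binding with a bare amino group

The compounds below may be only part of what the source reports. "The series", "measured", "known", "first", "only" and "open" are said of these compounds alone.

In an ADME assay on a cell-free system (plasma, Rattus norvegicus) for protein binding, compound 1 `CNc1nccc(N2CC[C@H](NC(=O)Nc3ccc(Cl)c(C(F)(F)F)c3)C2)n1`, which carries methylamino, gives 99.7%. Compound 2 `O=C(Nc1ccc(Cl)c(C(F)(F)F)c1)N[C@H]1CCN(c2ccnc(NC3CC3)n2)C1`, which carries cyclopropylamino at the same carbon, gives 99.9%. Compound 3 `O=C(Nc1ccc(Cl)c(C(F)(F)F)c1)N[C@H]1CCN(c2ccncn2)C1` has only hydrogen there and gives 99.4%. Values this close to complete binding are best read through the small fraction left free. On that reading, compound 3 stands level with compound 1 and has more free compound than compound 2.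

The next structure is compound 4 `Nc1nccc(N2CC[C@H](NC(=O)Nc3ccc(Cl)c(C(F)(F)F)c3)C2)n1`, which differs from compound 3 in one place: amino in place of hydrogen on an aromatic carbon. Amino replaces hydrogen on an aromatic carbon, turning pyrimidin-4-yl into 2-aminopyrimidin-4-yl. Amino is methylamino without its methyl, so the nearest guide is a 2.0-fold higher unbound fraction from compound 1 to compound 3 (0.30 log units; within the scatter), a step that stays within the scatter. The larger a 6.0-fold higher unbound fraction from compound 2 to compound 3 (0.78 log units; beyond the scatter) involves cyclopropylamino, a group further from amino, as does a 3.0-fold lower unbound fraction from compound 1 to compound 2 (0.48 log units; beyond the scatter). These steps suggest a slight lean towards less free compound, but no clear shift. The expected change is a 1.2-fold lower unbound fraction from compound 3 to compound 4 (0.08 log units; within the scatter), which would stay within the scatter. The estimate for compound 4 is 99.5%, with a range from 99% to 99.8%.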

Compound 4, plasma protein binding in the Rattus norvegicus assay: 99.4%
Compound 4: the middle estimate sits 1.2-fold (0.08 log units) (unbound fraction) below what was measured; low and high end bracket the measured number.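

In the Rattus norvegicus assay, amino on the aromatic carbon between two ring nitrogen atoms proves neutral, with no change at the digits printed from compound 3 to compound 4 (within the scatter), so a bare nitrogen donor at this position does not by itself pull the compound further onto plasma protein. The substituent on that nitrogen then becomes the point of interest: in the Rattus norvegicus assay, taking away cyclopropyl gives a 6.0-fold higher unbound fraction from compound 2 to compound 4 (0.78 log units; beyond the scatter), a step beyond the scatter, whereas taking away methyl gives a 2.0-fold higher unbound fraction from compound 1 to compound 4 (0.30 log units; within the scatter), a step that stays within it. The turn from pyrimidin-4-yl to 2-aminopyrimidin-4-yl, which leaves the free fraction where it was, does separate the two compounds clearly in a physicochemical assay for solubility, measured as kinetic solubility; on this read-out lower numbers stand for lower solubility and higher numbers for higher solubility: the measured solubility of compound 3, 2400 nM, and of compound 4, 30300 nM, a 13-fold higher number (1.10 log units; beyond the scatter) In the physicochemical assay, compound 3 gives 2400 nM and compound 4 gives 30300 nM.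

The compounds shown leave open whether this gain in the physicochemical assay belongs to amino alone or carries over to methylamino and cyclopropylamino. They also leave open how a hydroxyl or a methoxy group on the same carbon would compare with amino, both in the free fraction and in solubility.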